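The source may report more compounds than this note shows. Statements on the series, on what has been measured and on what is new or still open speak of the compounds shown alone.

Going by the values given here, in a functional assay on MCF7 cells (Homo sapiens) for antiproliferative activity, read by MTT assay, with a stated time of 72 h (a higher number here means a weaker inhibitor, a lower number a stronger inhibitor), only two compounds sharing one core have numbers so far. Compound 1 (`CCOc1ccc(-c2ccc3ncn(-c4cc(OC)c(OC)c(OC)c4)c3c2)cc1`) gives 1710 nM and compound 2 (`COc1cc(-n2cnc3ccc(-c4cc(F)ccc4F)cc32)cc(OC)c1OC`) gives 6420 nM on the same read-out. Compound 2 therefore holds the higher of the two numbers and is the weaker inhibitor of the pair. Compound 3 (`COc1cc(-n2cnc3ccc(-c4ccc(C(F)(F)F)cc4)cc32)cc(OC)c1OC`) changes compound 2 at one place, with 4-(trifluoromethyl)phenyl in place of 2,5-difluorophenyl on an aromatic carbon. Just one measured step bears on this change. That step is a 3.8-fold higher number from compound 1 to compound 2 (0.57 log units; beyond the scatter) and it is modest but beyond the usual scatter. It shows that this aromatic carbon can shift the number when the 2,5-difluorophenyl is involved. The entering group is 4-substituted, like the 4-ethoxyphenyl of compound 1 at 1710 nM in this assay, yet trifluoromethyl is not ethoxy, so only part of that gap is expected to return. The expected change is small and towards a lower number, namely a 1.6-fold lower number from compound 2 to compound 3 (0.21 log units; within the scatter) and it may not clear the scatter. Compound 3 is estimated at 4000 nM in this assay with an expected range from 1300 nM to 12000 nM on this single precedent.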

Compound 3, half-maximal inhibitory concentration: 760 nM
Compound 3: middle estimate off by 5.3-fold (0.72 log units), on the high side, outside the stated range (below it).
By their numbers in this assay, from the lowest: compound 3; then compound 1; then compound 2.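

In this assay, replacing 2,5-difluorophenyl with 4-(trifluoromethyl)phenyl on this aromatic carbon gives an 8.4-fold lower number from compound 2 to compound 3 (0.93 log units; beyond the scatter), so the position can move the number downward as well as upward, and by more than the earlier pair suggested. Replacing ethoxy with trifluoromethyl gives a 2.3-fold lower number from compound 1 to compound 3 (0.35 log units; beyond the scatter), which shows that among these three compounds the lowest number does not depend on an ethoxy group, and that two quite different groups on this phenyl ring both beat the 2,5-difluorophenyl of compound 2. The data shown offer no measured explanation for either step.

The step away from 2,5-difluorophenyl alters both the groups on the phenyl ring and where they sit, so these three compounds cannot separate the effect of group identity from that of placement. A plain phenyl, a 4-fluorophenyl or a 2-(trifluoromethyl)phenyl would help separate them, while a 4-aminophenyl or a 4-carboxyphenyl would test whether this position accepts a very different kind of group.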